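Cytotoxicity After Removing an Octyl Chain

The source may hold more compounds than are shown below. What is called first, only, known or untested is meant among the compounds shown, and "the series" means these compounds.

Of the compounds shown here, three built on a shared core have been tested for harm to human lung fibroblast cells. Compound 1 `CCCCCCCC1C(CO[C@@H]2O[C@@H]3CO[C@H](c4ccccc4)O[C@@H]3[C@H](OCc3ccccc3)[C@H]2O)N1S(=O)(=O)c1ccc(C)cc1` reaches only a limit of the assay: in an ADME assay on MRC5 cells (Homo sapiens) for cytotoxicity, read by MTT assay, with a stated time of 48 h (a higher number here means a weaker inhibitor, a lower number a stronger inhibitor), compound 1 gives > 1000000 nM. That reading is the limit of > 1000000 nM in this assay, at which 1 of the 3 values shown sits. Compound 2 `CCCCCCCCCC1(CO[C@@H]2O[C@@H]3CO[C@H](c4ccccc4)O[C@@H]3[C@H](OCc3ccccc3)[C@H]2OCc2ccccc2)CN1S(=O)(=O)c1ccc(C)cc1` gives 575000 nM in this assay. Compound 3 `Cc1ccc(S(=O)(=O)N2C(C)C2CO[C@@H]2O[C@@H]3CO[C@H](c4ccccc4)O[C@@H]3[C@H](O)[C@H]2O)cc1` gives 544000 nM in this assay. Of the two actual numbers, compound 2 stands highest, but its distance from compound 3 lies within the scatter, so the two cannot be told apart.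

Compound 4 `Cc1ccc(S(=O)(=O)N2CC2(C)CO[C@@H]2O[C@@H]3CO[C@H](c4ccccc4)O[C@@H]3[C@H](OCc3ccccc3)[C@H]2OCc2ccccc2)cc1` is not yet measured. It differs from compound 2 in one place: hydrogen in place of octyl on a saturated chain carbon bound to a saturated ring carbon. Among the measured compounds shown here, no step between measured compounds is available to set this change against. The step from compound 2 to compound 4 is expected to be small, a 1.1-fold higher number from compound 2 to compound 4 (0.05 log units; within the scatter), not beyond the scatter in either direction. Compound 4 is therefore estimated at 650000 nM in this assay, with a range from 250000 nM to 1500000 nM.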

Compound 4, half-maximal inhibitory concentration: > 1000000 nM
Compound 4: a limit, no number; the forecaster's own chance of this, stated with the estimate: 35%; middle value at least 1.5-fold (0.18 log units) away from the limit.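

Taking octyl away and putting hydrogen in its place, the same difference that reads nonyl to methyl, gives the first step at this position in this assay, and it gives an at least 1.7-fold higher number from compound 2 to compound 4 (0.24 log units; that floor lies within the scatter). On these data alone, compound 4 reads > 1000000 nM, which is a limit and not a number, so only a floor on the step is known and its true size stays unknown. What the result does show is that this change yields no lower number, and the reading stays at the top of what the assay can report: the limit of > 1000000 nM in this assay, at which 2 of the 4 values shown sit.

As far as these compounds go, only octyl and hydrogen are compared at this place, so how the number follows chain length remains open. From the compounds shown here alone, it is also open whether a butyl chain, an amine or a carboxylic acid there would bring the number down.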